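The source may report more compounds than this note shows. Statements on the series, on what has been measured and on what is new or still open speak of the compounds shown alone.

Compound 1 `C#CCSc1nc(Nc2ccc(C)cc2)c2ccncc2n1`: 6170 nM
Compound 2 `C#CCSc1nc(Nc2ccc(F)cc2)c2ccncc2n1`: 10800 nM

In a functional assay on HepG2 cells (Homo sapiens) for inhibition, read by MTT assay, with a stated time of 72 h (a lower number here means a stronger inhibitor, a higher number a weaker inhibitor), compound 1 gives the lower of the two numbers; compound 2, with fluoro in place of methyl, shows a 1.8-fold higher number from compound 1 to compound 2 (0.24 log units; within the scatter). Compound 3 `C#CCSc1nc(Nc2ccc(Br)cc2)c2ccncc2n1` is the next case: bromo in place of methyl on an aromatic carbon. Among the measured compounds shown here, the only measured step at this same place, the one from compound 1 to compound 2, stays within the scatter, so the swap to bromo is expected to move the number little, with a 1.1-fold higher number from compound 1 to compound 3 (0.05 log units; within the scatter). Compound 3 is therefore estimated at 7000 nM, within a range from 3000 nM to 16000 nM.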

Compound 3, half-maximal inhibitory concentration: 56200 nM
Beside the measured number, compound 3's estimate is 8.0-fold (0.90 log units) below it; measured number outside the range, above it.
By their numbers in this assay, from the lowest: compounds 1 and 2 (each within the scatter of the next); then compound 3.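

In this assay this position proves sensitive to the group it carries: bromo gives a 9.1-fold higher number from compound 1 to compound 3 (0.96 log units; beyond the scatter) and a 5.2-fold higher number from compound 2 to compound 3 (0.72 log units; beyond the scatter) while the earlier swap between methyl and fluoro stayed within the scatter. A small step at one place therefore did not foretell the next step at that same place. Nothing at hand explains why bromo stands apart here. From the compounds shown here alone, whether chloro would sit with fluoro or with bromo stays open. So does the outcome with a methoxy group or an amine at this place.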